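A Ring Amine Swap and Expected Cell Toxicity

The source may report more compounds than this note shows. Statements on the series, on what has been measured and on what is new or still open speak of the compounds shown alone.

Two esters of a shared core have been tested in an ADME assay on MDCK cells (Canis lupus familiaris) for cytotoxicity, read by MTT assay, with a stated time of 48 h; on this read-out lower numbers stand for higher toxicity in this test and higher numbers for lower toxicity in this test. Compound 1 `CC1(C)[C@H]2CC[C@]1(C)[C@H](OC(=O)CN1CCCC1)C2` gives 302000 nM in this assay, the highest of the two numbers, while compound 2 `CCCCN(CCCC)CCC(=O)O[C@@H]1C[C@@H]2CC[C@@]1(C)C2(C)C` gives 41800 nM, a gap beyond the usual scatter. Compound 3 `CC1(C)[C@H]2CC[C@]1(C)[C@H](OC(=O)CN1CCNCC1)C2` differs from compound 1 in one place: piperazin-1-yl in place of pyrrolidin-1-yl on a saturated chain carbon bound to a carbonyl carbon. Among the measured compounds shown here, no measured pair shows what such a change does in this assay, so only a small step is expected from compound 1 to compound 3, with no direction favoured beyond the scatter. The expected step is a 1.2-fold lower number from compound 1 to compound 3 (0.08 log units; within the scatter). Compound 3 is estimated at 250000 nM, within 100000 nM to 600000 nM.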

Compound 3, half-maximal cytotoxic concentration: 51600 nM
Compound 3: middle estimate off by 4.8-fold (0.69 log units), on the high side; the measured number lies below the stated range.
By their numbers in this assay, from the lowest: compounds 2 and 3 (each within the scatter of the next); then compound 1.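

On the shared core, the amine ring at this place clearly matters in this assay: piperazin-1-yl in place of pyrrolidin-1-yl gives a 5.9-fold lower number from compound 1 to compound 3 (0.77 log units; beyond the scatter), so this one swap is enough to raise toxicity in this test. The earlier pair differed in more than one place and could not show this. Nothing measured here explains the step. Still open, going by these compounds, is whether the larger ring or the added ring nitrogen carries it. Piperidin-1-yl, a six-membered ring with one nitrogen, would separate these two changes.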